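A few compounds are considered here, and "the series" means these few. Any claim that something is new, unique, unknown or untested is made for them only; others in the source may bear on it.

In an in vitro ADME assay on microsomes from liver (Mus musculus) for pharmacokinetics, read by LC-MS, with a stated time of 10 min, tested at 1 uM (on this read-out lower numbers stand for slow clearance and higher numbers for fast clearance), three amides sharing one core have been measured. Compound 1 `CN1C[C@H](C(=O)Nc2cccc(Cl)c2)[C@@H](c2ccc(/C=C/C(=O)Nc3ccccc3N)cc2)C1` gives 58 mL/min/kg, compound 2 `Cc1cccc(NC(=O)[C@H]2CN(C)C[C@@H]2c2ccc(/C=C/C(=O)Nc3ccccc3N)cc2)c1` gives 74 mL/min/kg and compound 3 `CN1C[C@H](C(=O)Nc2ccc(Cl)c(Cl)c2)[C@@H](c2ccc(/C=C/C(=O)Nc3ccccc3N)cc2)C1` gives 36 mL/min/kg. Compound 3 is set apart only from compound 2: a 2.1-fold lower number from compound 2 to compound 3 (0.31 log units; beyond the scatter). Against compound 1 it cannot be separated, as a 1.6-fold lower number from compound 1 to compound 3 (0.21 log units; within the scatter) shows.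

Compound 4 `CN1C[C@H](C(=O)Nc2ccc(F)cc2F)[C@@H](c2ccc(/C=C/C(=O)Nc3ccccc3N)cc2)C1` keeps the core and alters only the aromatic group of the amide: 2,4-difluorophenyl in place of 3,4-dichlorophenyl on an amide-type nitrogen. In words, 2,4-difluorophenyl stands in place of 3,4-dichlorophenyl on an amide-type nitrogen.

All three measured steps bear on this change. They alter that same aromatic group. They are small: besides the two already given, there is a 1.3-fold higher number from compound 1 to compound 2 (0.11 log units; within the scatter). Going by the values given here, none of the measured compounds carries fluorine, so the data offer no direct precedent for the incoming group. With the largest step only modest, no change beyond the scatter is expected in this assay, and any drift is expected to run slightly upward, toward the number of compound 1 at 58 mL/min/kg. The expected move is a 1.4-fold higher number from compound 3 to compound 4 (0.14 log units; within the scatter). For compound 4 the estimate is 50 mL/min/kg, with an expected range from 27 mL/min/kg to 85 mL/min/kg.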

Compound 4, clearance: 27 mL/min/kg
Compound 4: middle estimate off by 1.9-fold (0.27 log units), on the high side; the measured number falls inside the stated range.
By their numbers in this assay, from the lowest: compounds 4, 3, 1 and 2 (each within the scatter of the next, the first and the last beyond it).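

In this assay, going by these compounds alone, the first fluorinated group at this amide nitrogen cannot be told apart from the 3,4-dichlorophenyl group, with a 1.3-fold lower number from compound 3 to compound 4 (0.12 log units; within the scatter), so exchanging one pair of halogens for the other leaves the clearance number unresolved in either direction. Compound 4 nevertheless separates from both singly substituted amides where compound 3 separated from only one, showing a 2.1-fold lower number from compound 1 to compound 4 (0.33 log units; beyond the scatter) and a 2.7-fold lower number from compound 2 to compound 4 (0.44 log units; beyond the scatter), which places 2,4-difluorophenyl clearly below the 3-chlorophenyl and 3-methylphenyl groups. The two dihalogenated compounds thus sit at the low end of the series, although compound 3 stays within the scatter of compound 1 and so only partly fits that pattern, and nothing shown explains why these numbers fall where they do.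

The halogen and its places on the ring change together in the step from compound 3 to compound 4, so the compounds shown cannot say which of the two matters, if either does. Also open, from the compounds shown here alone, is how a methoxy group, a nitrile or a pyridine ring would read on this amide nitrogen, since all four aromatic groups here are substituted phenyl rings carrying only halogen or methyl.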